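From pyridin-3-yl to thiophen-2-yl: an expected outcome

The source may report more compounds than this note shows. Statements on the series, on what has been measured and on what is new or still open speak of the compounds shown alone.

Compound 1 `CS(=O)(=O)c1ccc(Cc2n[nH]c(=S)n2/N=C/c2cccnc2)cc1` was tested in a functional assay on HeLa cells (Homo sapiens) for cytotoxicity, read by MTT assay, with a stated time of 48 h, tested at 12.5 uM (a higher number here means a stronger effect of the compound at the concentration tested, a lower number a weaker effect), where compound 1 gives 16.9%. This is the lower of the two numbers available: compound 2 `COc1ccc2cc(/C=N/n3c(Cc4ccc(S(C)(=O)=O)cc4)n[nH]c3=S)ccc2c1` gives 43.7% in this assay, a gap that lies beyond the usual scatter. Compound 3 `CS(=O)(=O)c1ccc(Cc2n[nH]c(=S)n2/N=C/c2cccs2)cc1` has not yet been measured. It differs from compound 1 in a single place: thiophen-2-yl in place of pyridin-3-yl on a carbon with a double bond to nitrogen. Within the data shown here, no measured pair shows this exact change, so there is no step to lean on. The expected step of a number 3.1 percentage points higher from compound 1 to compound 3 (within the scatter) is small, without a direction that rises beyond the scatter. Compound 3 is therefore estimated at 20%, within a range from 6% to 38%.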

Compound 3, a percentage reported as activity, at one concentration (the size of the read-out at that concentration, not a potency): 28.7%
Estimate against measurement, compound 3: 8.7 percentage points below, and the stated range covers the measured number.
By their numbers in this assay, from the lowest: compound 1; then compound 3; then compound 2.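

In this assay thiophen-2-yl in place of pyridin-3-yl gives a number 11.8 percentage points higher from compound 1 to compound 3 (beyond the scatter) and so shows that, with the rest of the molecule unchanged, exchanging one aromatic ring for another at this place can shift the read-out. The step is modest, and a single pair sets no trend. Nothing available explains why the five-membered sulfur-containing ring gives the higher number.

The compounds shown leave open how a furan-2-yl ring or a thiophen-3-yl ring would behave here. They also leave open whether a ring is needed at all, as a plain propyl chain would test.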